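The compounds below may be only part of what the source reports. "The series", "measured", "known", "first", "only" and "open" are said of these compounds alone.

Compound 1 `O=C(c1ccccn1)N1CCC(NS(=O)(=O)c2cc(S(=O)(=O)c3ccccc3)ccc2C(F)(F)F)CC1` was tested in an assay on U2OS cells for inhibition of secreted frizzled-related protein 1 (Homo sapiens), read by a luciferase reporter, with a stated time of 18 h (a lower number here means that less compound is needed, a higher number that more compound is needed for the effect), and gave 230 nM. Compound 2 `N#Cc1cccc(S(=O)(=O)N2CCC(NS(=O)(=O)c3cc(S(=O)(=O)c4ccccc4)ccc3C(F)(F)F)CC2)c1` gave 170 nM in this assay. Among the measured compounds shown here, compound 1 thus holds the highest of the two numbers known, and the only step that connects them, a 1.4-fold lower number from compound 1 to compound 2 (0.13 log units; within the scatter), stays within the scatter. Compound 3 `CC(C)(O)CCN1CCC(NS(=O)(=O)c2cc(S(=O)(=O)c3ccccc3)ccc2C(F)(F)F)CC1` differs from compound 1 as follows: 3-hydroxy-3-methylbutyl in place of (pyridin-2-yl)carbonyl on an amine nitrogen in a ring. For the measured compounds named here, no measured step involves 3-hydroxy-3-methylbutyl, so the one step recorded, a 1.4-fold lower number from compound 1 to compound 2 (0.13 log units; within the scatter), bears only loosely on this change. Compound 3 is therefore expected to need somewhat more compound, with a 2.6-fold higher number from compound 1 to compound 3 (0.42 log units; beyond the scatter) as the expected step. The estimate for compound 3 is 600 nM, in a range from 200 nM to 2500 nM.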

Compound 3, half-maximal effective concentration: 630 nM
Compound 3: the middle estimate sits 1.1-fold (0.02 log units) below what was measured, within the range that was stated.
By their numbers in this assay, from the lowest: compounds 2 and 1 (each within the scatter of the next); then compound 3.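

In this assay the amine nitrogen in the ring still carries a group with no ring, 3-hydroxy-3-methylbutyl, but the number rises: the data show a 2.7-fold higher number from compound 1 to compound 3 (0.44 log units; beyond the scatter) and also a 3.7-fold higher number from compound 2 to compound 3 (0.57 log units; beyond the scatter) and both steps are modest. Unlike the exchange of the two earlier groups, which stayed within the scatter, this change at the same position goes beyond it. Nothing measured here accounts for the rise.

Still open, on these data alone, is whether the hydroxyl or the chain matters, which a plain 3-methylbutyl chain or a shorter hydroxyalkyl chain would separate. A basic amine or a carboxylic acid at this nitrogen also remains to be compared.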